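A few compounds are considered here, and "the series" means these few. Any claim that something is new, unique, unknown or untested is made for them only; others in the source may bear on it.

In a functional assay on the whole organism for antagonist activity, with Mus musculus as the target (on this read-out lower numbers stand for an effect already at smaller amounts and higher numbers for an effect only at larger amounts of compound), compound 3 (`COC(=O)N(C)C(C)C#CCn1ccnc1`) reports only a limit, > 100 mg/kg. Compound 2 (`COC(=O)N(C)C(C)C#CCN1CCCC1`) also reports only a limit, > 100 mg/kg. Compound 1 (`COC(=O)N(C)CC#CCN(C)C`) likewise reports only a limit, > 30 mg/kg. For the measured compounds named here, the one measured step that bears on the next change, a step that the two limits leave unreadable from compound 2 to compound 3, has no readable size, so it offers no size to carry over. Compound 4 (`COC(=O)N(C)C(C)C#CCN(C)C`) has dimethylamino in place of 1H-imidazol-1-yl on a saturated chain carbon bound to a triple-bonded carbon. In this assay, the expected change is only a small one toward smaller amounts, an at least 1.2-fold lower number from compound 3 to compound 4 (0.09 log units; that floor lies within the scatter), and another limit remains likely. Compound 4 is estimated at 80 mg/kg, with an expected range from 15 mg/kg to 300 mg/kg.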

Compound 4, dose for half-maximal effect: > 100 mg/kg
Compound 4: a limit, no number; the forecaster's own chance of this, stated with the estimate: 60%; middle value at least 1.2-fold (0.09 log units) away from the limit.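

For the compounds shown here, compound 1, compound 2, compound 3 and compound 4 all give only a limit in this assay, and no step among them can be read. The compounds shown leave open whether any of these changes shifts the dose for half-maximal effect.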